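The compounds below may be only part of what the source reports. "The series", "measured", "known", "first", "only" and "open" are said of these compounds alone.

Measured so far: compound 1 `CC1C(=O)N(C)c2cnc(Nc3ccc(S(N)(=O)=O)cc3)nc2N1C`, 313 nM; compound 2 `COc1cccc(C2C(=O)N(C)c3cnc(Nc4ccc(S(N)(=O)=O)cc4)nc3N2C)c1`, 954 nM.

Among the measured compounds shown here, in an assay on Sf9 cells for inhibition of serine/threonine-protein kinase 4 (Homo sapiens), read by luminescence and ADP-Glo, with a stated time of 1 h, in the presence of a further agent that is not named here (on this read-out higher numbers stand for weaker inhibition and lower numbers for stronger inhibition), compound 2 holds the higher of the two numbers; the only measured step, a 3.0-fold higher number from compound 1 to compound 2 (0.48 log units; beyond the scatter), is modest. Compound 3 `Cc1ccc(F)cc1C1C(=O)N(C)c2cnc(Nc3ccc(S(N)(=O)=O)cc3)nc2N1C` carries 5-fluoro-2-methylphenyl in place of 3-methoxyphenyl on a saturated ring carbon. For the measured compounds named here, no measured step exchanges one aryl group for another on that saturated ring carbon, so this change has no direct precedent; the single known step from compound 1 to compound 2 covers methyl against aryl only. No shift beyond the scatter is therefore expected, with a 1.1-fold lower number from compound 2 to compound 3 (0.03 log units; within the scatter) as the estimated change. For compound 3 the expected value is 900 nM, range 300 nM to 2700 nM.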

Compound 3, half-maximal inhibitory concentration: 168 nM
The estimate for compound 3 lay 5.4-fold (0.73 log units) above the measured number; the measured number lies below the stated range.
By their numbers in this assay, from the lowest: compounds 3 and 1 (each within the scatter of the next); then compound 2.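

In this assay the saturated ring carbon distinguishes between aryl groups: 5-fluoro-2-methylphenyl in place of 3-methoxyphenyl gives a 5.7-fold lower number from compound 2 to compound 3 (0.75 log units; beyond the scatter) and not a shift within the scatter. With 5-fluoro-2-methylphenyl in place of methyl, a 1.9-fold lower number from compound 1 to compound 3 (0.27 log units; within the scatter) and so an aryl group at this position does not always give a higher number than methyl. Nothing at hand accounts for the gap between the two aryl groups.

On these data alone, the methyl and the fluorine of 5-fluoro-2-methylphenyl enter together, and their separate contributions remain open. Also open, as far as these compounds go, is how an unsubstituted phenyl, or an aryl group bearing a carboxylic acid or an amine, would read at this carbon.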